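Swapping the aryl group on the triazole-free comparison

A few compounds are considered here, and "the series" means these few. Any claim that something is new, unique, unknown or untested is made for them only; others in the source may bear on it.

Hmm, that title names a ring the data do not print, so the piece is given with this title instead:

One aryl swap, from compound 2 to compound 3

Measured so far in a functional assay on MCF7 cells (Homo sapiens) for antiproliferative activity, read by MTT assay; on this read-out higher numbers stand for weaker inhibition and lower numbers for stronger inhibition:

compound 1 `COc1ccc(-n2cc(COc3ccc(/C=C/C(=O)c4ccc5c(c4O)CCC(C)(C)O5)cc3)nn2)c([N+](=O)[O-])c1`: 73100 nM
compound 2 `CC(=O)c1ccc(-n2cc(COc3ccc(/C=C/C(=O)c4ccc5c(c4O)CCC(C)(C)O5)cc3)nn2)cc1`: 171000 nM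

Of these two, compound 2 has the higher number at 171000 nM, which makes it the weaker inhibitor of the pair. Going by the values given here, its only neighbour is compound 1 at 73100 nM.

The next compound to be tested is compound 3 `CCc1ccccc1-n1cc(COc2ccc(/C=C/C(=O)c3ccc4c(c3O)CCC(C)(C)O4)cc2)nn1`. It differs from compound 2 in a single place: 2-ethylphenyl in place of 4-acetylphenyl on an aromatic nitrogen. In short, 2-ethylphenyl sits in place of 4-acetylphenyl on an aromatic nitrogen.

Among the compounds with values here, only one measured step changes the group at this same place: a 2.3-fold higher number from compound 1 to compound 2 (0.37 log units; beyond the scatter). That step was modest, and it is a single example that involves neither the ethyl group nor any close relative of it. The data therefore give only a weak hint. A step of similar modest size seems reasonable, and a slight drift back toward compound 1 is the likeliest direction. The expected change in this assay is a 1.6-fold lower number from compound 2 to compound 3 (0.19 log units; within the scatter). For compound 3 the estimated value is 110000 nM, with an expected range from 45000 nM to 260000 nM.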

Compound 3, half-maximal inhibitory concentration: "not active" (no number reported)
Nothing numeric was reported for compound 3; no gap can be computed for the estimate.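

In this assay, going by these compounds alone, compound 3 is reported only as "not active", without a number, so no step from compound 2 to compound 3 can be read. Going by these compounds, how 2-ethylphenyl compares with 4-acetylphenyl at this place, in direction and in size, stays open. Nothing shown offers an explanation for this result.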